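The compounds below may be only part of what the source reports. "The series", "measured", "known", "first", "only" and "open" are said of these compounds alone.

The measured compounds:
compound 1, `CNC(=O)c1cc(C(=O)NC2CC2)cn(Cc2cccc(F)c2)c1=O`, gives 3.2
compound 2, `CNC(=O)c1cc(C(=O)NCCC2CCOCC2)cn(Cc2ccccc2)c1=O`, gives 3.6
compound 3, `CNC(=O)c1cc(C(=O)NC2CC2)cn(Cc2cccc3[nH]c(C)nc23)c1=O`, gives 1.5

In a physicochemical assay for lipophilicity, at pH 7.4 (on this read-out lower numbers stand for lower lipophilicity and higher numbers for higher lipophilicity), compound 1 stands second highest of the three: compound 2 sits above it beyond the scatter, and compound 3 lies far below it, also beyond the scatter. Compound 4, `CNC(=O)c1cc(C(=O)NC2CC2)cn(Cc2cccc(C#N)c2)c1=O`, has not yet been measured. It differs from compound 1 in one place: cyano in place of fluoro on an aromatic carbon. Among the compounds with values here, no two measured compounds differ in only one place, so no measured step guides this change directly. In this assay the step is expected to be a moderate drop, beyond the scatter, of about a number 0.70 log units lower from compound 1 to compound 4 (beyond the scatter). Compound 4 is therefore estimated at 2.5, within a range from 2.1 to 2.9.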

Compound 4, distribution coefficient: 2.6
The estimate for compound 4 lay 0.10 log units below the measured number; low and high end bracket the measured number.
By their numbers in this assay, from the lowest: compound 3; then compound 4; then compound 1; then compound 2.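

In this assay, within the data shown here, cyano in place of fluoro on this aromatic carbon gives a number 0.60 log units lower from compound 1 to compound 4 (beyond the scatter) and is the first step here that isolates a single change. With the rest of compound 1 kept the same, the group on this one ring carbon is enough to move the read-out beyond the usual scatter. No measurement at hand explains the drop. From the compounds shown here alone, how a methoxy group or an amine at this place would compare with fluoro and cyano stays open, as does whether the same swap gives a similar step on another ring carbon.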